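Quinolinyl amide on a piperidinyloxy scaffold: expectation from limits

The compounds below may be only part of what the source reports. "The series", "measured", "known", "first", "only" and "open" are said of these compounds alone.

Measured compounds:
compound 1 `Cc1ccc(NC(=O)c2cccc(C(F)(F)F)c2)cc1OC1CCN(C(=O)c2cccnc2)CC1` — > 10000 nM
compound 2 `Cc1ccc(NC(=O)c2cccc(C(F)(F)F)c2)cc1OC1CCN(C(=O)c2ccccn2)CC1` — > 10000 nM
compound 3 `CCC(=O)N1CCC(Oc2cc(NC(=O)c3cccc(C(F)(F)F)c3)ccc2C)CC1` — > 10000 nM

Compound 1 is known only as a limit. In an ADME assay on BaF3 cells (Mus musculus) for antiproliferative activity (on this read-out lower numbers stand for stronger inhibition of growth and higher numbers for weaker inhibition of growth), compound 1 gives > 10000 nM, which is a limit of the assay and not a number. Compound 2 likewise reaches only a limit there. Compound 3 also stops at a limit. Accordingly a step that the two limits leave unreadable from compound 1 to compound 2, a step that the two limits leave unreadable from compound 1 to compound 3 and a step that the two limits leave unreadable from compound 2 to compound 3 cannot be read, and all three values share (the limit of > 10000 nM in this assay, at which 3 of the 3 values shown sit).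

Compound 4 `Cc1ccc(NC(=O)c2cnc3ccccc3c2)cc1OC1CCN(C(=O)c2cccnc2)CC1` differs from compound 1 by quinolin-3-yl in place of 3-(trifluoromethyl)phenyl on a carbonyl carbon. Among the measured compounds shown here, none of the measured steps touches this carbonyl, and none yields a readable size. With compound 1 at the limit, compound 4 is expected to remain near it, giving 12000 nM with a range from 3000 nM to 30000 nM. This estimate means the step that the limit leaves unreadable from compound 1 to compound 4 is expected, though it rests on limits alone.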

Compound 4, concentration for 50% growth inhibition: > 10000 nM
Compound 4 was reported as a limit; the forecaster's own chance of this, stated with the estimate: 70%; the middle value lies beyond the limit too.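

Compound 1 and compound 4 both stop at a limit of the assay, so no size can be read for the step between them: the limit of > 10000 nM in this assay, at which 4 of the 4 values shown sit.

The compounds shown leave open how strongly any of them inhibits growth in this assay, and whether either carbonyl change alters it.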